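Isopropylsulfonyl in place of isopropoxycarbonyl: expected maximal response

The source may hold more compounds than are shown below. What is called first, only, known or untested is meant among the compounds shown, and "the series" means these compounds.

Measured so far in a functional assay on CHO-K1 cells with Glucose-dependent insulinotropic receptor (Homo sapiens) as the target, read by a luciferase reporter, with a stated time of 5 h; on this read-out higher numbers stand for larger maximal responses and lower numbers for smaller maximal responses:
Compound 1 `CC(C)OC(=O)N1CCC(Oc2ncnc3c2CCN3c2ccc(S(C)(=O)=O)cc2F)CC1` gives 91%.
Compound 2 `CCOC(=O)N1CCC(Oc2ncnc3c2CCN3c2ccc(S(C)(=O)=O)cc2F)CC1` gives 135%.
Compound 3 `CSC(=O)N1CCC(Oc2ncnc3c2CCN3c2ccc(S(C)(=O)=O)cc2F)CC1` gives 135%.

Compound 1 stands lowest of the three numbers. The step of a number 44 percentage points higher from compound 1 to compound 2 (beyond the scatter) and the step of a number 44 percentage points higher from compound 1 to compound 3 (beyond the scatter) are both beyond the scatter and of the same size, while the step of no change at the digits printed from compound 2 to compound 3 (within the scatter) lies within the scatter. Compound 4 `CC(C)S(=O)(=O)N1CCC(Oc2ncnc3c2CCN3c2ccc(S(C)(=O)=O)cc2F)CC1` differs from compound 1 by isopropylsulfonyl in place of isopropoxycarbonyl on an amine nitrogen in a ring. Going by the values given here, no measured step exchanges the carbonyl-bearing group for a sulfonyl, so none bears on this change directly. The two measured steps at the same ring nitrogen show that varying the group there moved the number upward by a large amount from compound 1 in both cases, whereas the step between compound 2 and compound 3 was within the scatter. On that basis a rise from compound 1 is plausible but its size is uncertain. Compound 4 is therefore expected to give about 115%, within a range of 85% to 150%. The expected step is a number 24 percentage points higher from compound 1 to compound 4 (beyond the scatter).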

Compound 4, largest response reached (reported as percent of maximum), in percent of the reference or control that the assay uses: 62%
Estimate against measurement, compound 4: 53 percentage points above; measured number outside the range, below it.
By their numbers in this assay, from the lowest: compound 4; then compound 1; then compounds 2 and 3 (each within the scatter of the next).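

In this assay, going by these compounds alone, isopropylsulfonyl in place of isopropoxycarbonyl on this ring nitrogen gives a number 29 percentage points lower from compound 1 to compound 4 (beyond the scatter) and is the first change here to lower the number from compound 1, since both earlier changes at this nitrogen raised it. The same exchange starting from the other carbonyl-bearing groups gives a number 73 percentage points lower from compound 2 to compound 4 (beyond the scatter) and also a number 73 percentage points lower from compound 3 to compound 4 (beyond the scatter) so the sulfonyl compound now sits under all three carbonyl-bearing compounds, and the position is shown to allow losses as well as gains in maximal response. Nothing at hand accounts for this fall.

Still open, on these data alone, is whether the fall follows the sulfonyl link or the isopropyl part, which compound 1 and compound 4 share. An ethylsulfonyl group on this nitrogen would separate the two, and a urea would show how a carbonyl linked through a second nitrogen behaves.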